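The source may report more compounds than this note shows. Statements on the series, on what has been measured and on what is new or still open speak of the compounds shown alone.

Compound 2 `Cc1ccc(NC(=O)c2ccc(/N=N\c3c[nH]c4ccccc34)cc2)cc1` is one of three related compounds tested in a functional assay on MCF7 cells (Homo sapiens) for inhibition, read by MTT assay, with a stated time of 72 h (on this read-out lower numbers stand for stronger inhibition and higher numbers for weaker inhibition), where compound 2 gives 42400 nM. Compound 1 `O=C(Nc1ccccc1)c1ccc(/N=N\c2c[nH]c3ccccc23)cc1` gives 147000 nM in this assay, and compound 3 `Cc1ccc(C)c(NC(=O)c2ccc(/N=N\c3c[nH]c4ccccc34)cc2)c1` gives 29900 nM. Among these three numbers compound 2 stands second highest: the step of a 3.5-fold lower number from compound 1 to compound 2 (0.54 log units; beyond the scatter) set it well apart from compound 1, while the step of a 1.4-fold lower number from compound 2 to compound 3 (0.15 log units; within the scatter) leaves compound 2 and compound 3 close together.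

The untested compound 4 `Cc1ccc(NC(=O)c2ccc(/N=N\c3c[nH]c4ccccc34)cc2)c(C)c1` differs from compound 2 by methyl in place of hydrogen on an aromatic carbon, the new group sitting ortho to a large group and meta to a methyl group. Within the data shown here, two measured steps bear on this change. Adding a first methyl gave a 3.5-fold lower number from compound 1 to compound 2 (0.54 log units; beyond the scatter); adding a second methyl in a different arrangement gave a 1.4-fold lower number from compound 2 to compound 3 (0.15 log units; within the scatter), and the two together gave a 4.9-fold lower number from compound 1 to compound 3 (0.69 log units; beyond the scatter). A second methyl thus appears to bring little further gain, so in this assay a step from compound 2 that stays within the scatter, or edges only slightly lower, is expected. Compound 4 is accordingly expected to give 32000 nM, within a range of 15000 nM to 65000 nM. That expectation corresponds to a 1.3-fold lower number from compound 2 to compound 4 (0.12 log units; within the scatter).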

Compound 4, half-maximal inhibitory concentration: 87000 nM
Beside the measured number, compound 4's estimate is 2.7-fold (0.43 log units) below it; the whole stated range lies below it.
By their numbers in this assay, from the lowest: compounds 3 and 2 (each within the scatter of the next); then compounds 4 and 1 (each within the scatter of the next).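

In this assay, a methyl on the aromatic carbon ortho to a large group of the 4-methylphenyl ring brings a 2.1-fold higher number from compound 2 to compound 4 (0.31 log units; beyond the scatter) and so moves the number the opposite way from the first methyl on the plain phenyl, which brought a 3.5-fold lower number from compound 1 to compound 2 (0.54 log units; beyond the scatter) in this series. Where the second methyl sits therefore matters: 2,4-dimethylphenyl in place of 2,5-dimethylphenyl brings a 2.9-fold higher number from compound 3 to compound 4 (0.46 log units; beyond the scatter) even though both rings carry the same two methyl groups. Set against the plain phenyl, the 2,4-dimethylphenyl ring shows a 1.7-fold lower number from compound 1 to compound 4 (0.23 log units; within the scatter) and so keeps no gain that stands clear of the scatter, unlike the 2,5-dimethylphenyl ring of compound 3.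

No measurement shown here explains why this position behaves differently. The compounds also leave open whether a different group at this same carbon, such as a fluorine, a methoxy group or a longer chain like ethyl, would raise the number as the methyl does or would leave it unchanged.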